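Acid for Amide: The Same Change on Two Cores

The compounds below may be only part of what the source reports. "The series", "measured", "known", "first", "only" and "open" are said of these compounds alone.

Measured so far in a functional assay on HeLa cells (Homo sapiens) for cytotoxicity, read by MTT assay, with a stated time of 24 h; on this read-out higher numbers stand for weaker inhibition and lower numbers for stronger inhibition:
Compound 1 `C=CC1=C(C(=O)NCc2ccccc2)C(c2ccc(OC)c(OC)c2)OC1` gives > 100000 nM.
Compound 2 `C=CC1=C(C(=O)O)C(c2ccc(OC)c(OC)c2)OC1` gives 18000 nM.
Compound 3 `C=CC1=C(C(=O)NCc2ccccc2)C(c2ccc(Cl)c(Cl)c2)OC1` gives > 100000 nM.

The value of compound 1 is a limit of the assay, not a number. The value of compound 3 is likewise a limit. This is the limit of > 100000 nM in this assay, at which 2 of the 3 values shown sit. Compound 1 and compound 2 differ in one place, (hydroxy in place of benzylamino on a carbonyl carbon), and the step gives an at least 5.5-fold lower number from compound 1 to compound 2 (0.74 log units; beyond the scatter). Compound 3 carries a different core than compound 1; the difference between the two cores is not broken down here. Compound 4 `C=CC1=C(C(=O)O)C(c2ccc(Cl)c(Cl)c2)OC1`, not yet measured, stands to compound 3 as compound 2 stands to compound 1: hydroxy in place of benzylamino on a carbonyl carbon. The change is the same, and its place is the same in both pairs. Since the value of compound 3 is only a limit, the step from compound 3 to compound 4 cannot be sized from its own pair; the expectation rests on compound 1 to compound 2, an at least 5.5-fold lower number from compound 1 to compound 2 (0.74 log units; beyond the scatter). Compound 4 is therefore expected to take a step of about an at least 3.3-fold lower number from compound 3 to compound 4 (0.52 log units; beyond the scatter), a value estimated near 30000 nM in this assay, with an expected range from 8000 nM to 100000 nM.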

Compound 4, half-maximal inhibitory concentration: 10300 nM
The estimate for compound 4 lay 2.9-fold (0.46 log units) above the measured number, and the stated range covers the measured number.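

In this assay, putting hydroxy in place of benzylamino on the carbonyl carbon gives a lower number on the second core as well, with an at least 9.7-fold lower number from compound 3 to compound 4 (0.98 log units; beyond the scatter). Compound 3 gives > 100000 nM, which is a limit of the assay and not a number. The two pairs therefore show that the change points the same way on both cores, but they do not show that it has the same size on each, and two pairs are a narrow base for any wider rule: the same change on two cores in this assay, an at least 5.5-fold lower number (0.74 log units; beyond the scatter) from compound 1 to compound 2 and an at least 9.7-fold lower number (0.98 log units; beyond the scatter) from compound 3 to compound 4; the limit leaves it open whether they differ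

Compound 1 and compound 3 both lack a true number, so the full size of each step stays unknown: the limit of > 100000 nM in this assay, at which 2 of the 4 values shown sit. The compounds shown also leave open whether another group on the carbonyl carbon, such as a methyl ester or a simple amine in place of benzylamino, would go with the hydroxy compounds or with the benzylamino compounds, and whether the same step holds with a single fluorine on the aromatic ring.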